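The source may report more compounds than this note shows. Statements on the series, on what has been measured and on what is new or still open speak of the compounds shown alone.

Measured in an in vitro ADME assay on microsomes from liver (Homo sapiens) for metabolic stability; on this read-out lower numbers stand for slow clearance and higher numbers for fast clearance: compound 1 `Cc1ccccc1-n1c(C)nnc1C1CCN(c2ccccn2)CC1` gives 33 mL.min-1.g-1; compound 2 `Cc1ccc(-n2c(C)nnc2C2CCN(c3ccccn3)CC2)cc1` gives 40 mL.min-1.g-1; compound 3 `Cc1nnc(C2CCN(c3ccccn3)CC2)n1-c1ccc(Cl)cc1` gives 23 mL.min-1.g-1.

Compound 2 stands at the highest of the three numbers, yet both of its gaps are within the scatter: a 1.2-fold higher number from compound 1 to compound 2 (0.08 log units; within the scatter) and a 1.7-fold lower number from compound 2 to compound 3 (0.24 log units; within the scatter). The third pair behaves the same way, a 1.4-fold lower number from compound 1 to compound 3 (0.16 log units; within the scatter). Every measured step thus changes only a substituent on a ring bound straight to the aromatic nitrogen, and none of them moves the read-out beyond the scatter.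

Compound 4 `Cc1nnc(C2CCN(c3ccccn3)CC2)n1Cc1cccc(Cl)c1` arises from compound 2 by a different kind of change: 3-chlorobenzyl in place of 4-methylphenyl on an aromatic nitrogen. Within the data shown here, no measured pair shows a benzyl in place of a phenyl at this position, so nothing in the three compounds points in either direction. Given that the three known steps all stayed within the scatter, compound 4 is expected to stay close to compound 2, with the step of no change at the digits printed from compound 2 to compound 4 (within the scatter) estimated as no change beyond the scatter. Among the measured compounds shown here, compound 4 is therefore estimated at 40 mL.min-1.g-1, in a range from 15 mL.min-1.g-1 to 110 mL.min-1.g-1, wide since the change has no measured precedent here.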

Compound 4, intrinsic clearance in microsomes: 29 mL.min-1.g-1
Compound 4: middle estimate off by 1.4-fold (0.14 log units), on the high side, and the stated range covers the measured number.
By their numbers in this assay, from the lowest: compounds 3, 4, 1 and 2 (each within the scatter of the next).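

In this assay, among these compounds, the first benzyl group at this position, 3-chlorobenzyl on the aromatic nitrogen, stays within the scatter of each of the three compounds with a phenyl group there (a 1.4-fold lower number from compound 2 to compound 4 (0.14 log units; within the scatter); a 1.3-fold higher number from compound 3 to compound 4 (0.10 log units; within the scatter); a 1.1-fold lower number from compound 1 to compound 4 (0.06 log units; within the scatter)). Across these four compounds, then, going from a phenyl ring bound straight to the aromatic nitrogen to a benzyl group does not move the read-out beyond the scatter, and no compound stands apart from the rest. Nothing at hand gives a reason for this result.

Every group shown at this position carries a six-membered aromatic ring of carbon only, so it remains open whether an amine, a carboxylic acid or a longer chain there would also stay within the scatter. With only one benzyl group shown, it is equally open whether an unsubstituted benzyl or a 4-chlorobenzyl would behave like 3-chlorobenzyl.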